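The source may hold more compounds than are shown below. What is called first, only, known or untested is meant among the compounds shown, and "the series" means these compounds.

Compound 2, with the structure `CCn1ccc(N2C[C@H](COC)OC2=O)c1`, gives 0.6 nM in an assay for inhibition of Amine oxidase [flavin-containing] A (Bos taurus), read by fluorescence, with a stated time of 30 min (on this read-out lower numbers stand for stronger inhibition and higher numbers for weaker inhibition), the lowest of the two numbers measured here. Compound 1, with the structure `C=CCn1ccc(N2C[C@H](CO)OC2=O)c1`, gives 350 nM in this assay; the two compounds differ in two places at once, so their values show only that the gap between them is wide. Compound 3, with the structure `C=CCn1ccc(N2C[C@H](COC)OC2=O)c1`, has not yet been measured in this assay. It differs from compound 2 by vinyl in place of methyl on a saturated chain carbon bound to an aromatic nitrogen. Going by the values given here, only one measured pair sits nearby and it changes two things together, so the weight carried by the chain on the aromatic nitrogen alone cannot be read off. The expected step from compound 2 to compound 3 is therefore small, a 2.5-fold higher number from compound 2 to compound 3 (0.40 log units; beyond the scatter), toward a slightly higher number. Compound 3 is expected to give about 1.5 nM in this assay, with a plausible range from 0.3 nM to 10 nM.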

Compound 3, inhibition constant: 1 nM
Compound 3: the middle estimate sits 1.5-fold (0.18 log units) above what was measured; the measured number falls inside the stated range.
By their numbers in this assay, from the lowest: compounds 2 and 3 (each within the scatter of the next); then compound 1.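

In this assay, vinyl in place of methyl on a saturated chain carbon bound to an aromatic nitrogen gives a 1.7-fold higher number from compound 2 to compound 3 (0.22 log units; within the scatter), so ethyl and allyl cannot be told apart at this place. Compound 3 also separates the two changes that were mixed between compound 1 and compound 2: methyl in place of hydrogen on an oxygen on a saturated carbon gives a 350-fold lower number from compound 1 to compound 3 (2.54 log units; beyond the scatter), so this change, rather than the chain on the aromatic nitrogen, accounts for the wide gap. Nothing available explains why that methyl matters so much.

From the compounds shown here alone, it remains open whether a longer chain or a benzyl group on the aromatic nitrogen would fit as well as ethyl and allyl. Going by these compounds, it is also open how an ethyl group on that oxygen, or an amine in place of the oxygen, would compare.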